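Methyl to cyano on the pendant phenyl ring: compound 4

A few compounds are considered here, and "the series" means these few. Any claim that something is new, unique, unknown or untested is made for them only; others in the source may bear on it.

Measured so far in a functional assay on DU-145 cells (Homo sapiens) for antiproliferative activity, read by sulforhodamine B assay, with a stated time of 72 h; a lower number here means a stronger inhibitor of growth, a higher number a weaker inhibitor of growth:
Compound 1 `Cc1cc(=O)oc2cc(Sc3cccc(Cl)[n+]3[O-])ccc12` gives > 31200 nM, a limit of the assay rather than a number.
Compound 2 `COc1cc(CSc2ccc3c(C)cc(=O)oc3c2)cc(OC)c1` gives > 29200 nM, again a limit of the assay.
Compound 3 `CCc1cc(=O)c2ccc(OCc3cccc(C)c3)c(C)c2o1` gives 24100 nM.

Among the compounds with values here, compound 3 therefore stands as the only member of the set with a number in this assay; the other two sit at limits, and no pair of measured compounds differs in one place, so no measured step exists to lean on. Compound 4 `CCc1cc(=O)c2ccc(OCc3cccc(C#N)c3)c(C)c2o1` differs from compound 3 by cyano in place of methyl on an aromatic carbon of a six-membered aromatic ring of carbon only; read one bond further out, the change is 3-methylphenyl to 3-cyanophenyl. Within the data shown here, with no comparable step in hand, the expectation is a step from compound 3 to compound 4 of no more than the usual scatter, in either direction, the estimated step being a 1.0-fold higher number from compound 3 to compound 4 (0.02 log units; within the scatter). Compound 4 is estimated at 25000 nM in this assay, with a range from 8000 nM to 80000 nM, and a fair chance that only a limit is reported.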

Compound 4, concentration for 50% growth inhibition: > 31300 nM
Compound 4: no number, only a limit; the forecaster's own chance of this, stated with the estimate: 40%; at least 1.2-fold (0.09 log units) between middle value and limit.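

This position on the pendant phenyl ring now has its first step in this assay, with an at least 1.2-fold higher number from compound 3 to compound 4 (0.11 log units; that floor lies within the scatter). The size is only a floor, so the change cannot be told apart from no change or from a larger loss. The cyano brings one hydrogen-bond acceptor that the methyl lacks, yet no stronger growth inhibition appears in the reading for compound 4, which is a limit of the assay and not a number: the limit of > 31300 nM in this assay, at which 1 of the 4 values shown sits.

Open, on these data alone, is how far past that limit compound 4 truly lies, so the real size of this step remains unknown. Also open, as far as these compounds go, is whether an amine, a carboxylic acid or a longer chain at this same place would give a readable number, and whether it would lie on the stronger side of compound 3.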